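The source may report more compounds than this note shows. Statements on the series, on what has been measured and on what is new or still open speak of the compounds shown alone.

Measured compounds:
Compound 1 `O=C(Nc1cccc(Cl)c1)c1cc(C(F)(F)F)ccc1OCc1ccc(F)cc1` gives 12.6 nM in an assay on Sf9 cells for inhibition of Leucine-rich repeat serine/threonine-protein kinase 2 (Homo sapiens), read by TR-FRET, with stated times of 30 min and 2 h; on this read-out lower numbers stand for stronger inhibition and higher numbers for weaker inhibition.
Compound 2 `O=C(Nc1ccnnc1)c1cc(N2CCC(CO)CC2)ccc1OCc1ccccc1` gives 20 nM in this assay.
Compound 3 `O=C(Nc1ccnnc1)c1cc(N2CCC(O)CC2)ccc1OCc1ccccc1` gives 39.8 nM in this assay.

Among these three, compound 3 carries the highest number. Going by the values given here, compound 2 sits nearest to it, and the single change between them, hydroxy in place of hydroxymethyl on a saturated ring carbon, reads a 2.0-fold higher number from compound 2 to compound 3 (0.30 log units; within the scatter), so the two compounds cannot be told apart on this read-out. Among the compounds with values here, compound 1 is the furthest away: its number lies lower than that of compound 3 by more than the scatter, but the two differ at several places and no single step connects them.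

Compound 4 `N#CC1CCN(c2ccc(OCc3ccccc3)c(C(=O)Nc3ccnnc3)c2)CC1` is reached from compound 3 by one change: cyano in place of hydroxy on a saturated ring carbon. Within the data shown here, the only measured step that bears on this position is the one from compound 2 to compound 3, which exchanged the group on the same saturated ring carbon and stayed within the scatter. Among the measured compounds shown here, no measured pair exchanges a hydroxy for a cyano, so the expectation leans on that single neighbouring step. For compound 4 this means an expected step of a 1.2-fold lower number from compound 3 to compound 4 (0.09 log units; within the scatter) in this assay, with no shift beyond the scatter foreseen. Compound 4 is accordingly estimated at 32 nM, with a range of 10 nM to 100 nM.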

Compound 4, half-maximal inhibitory concentration: 10 nM
Compound 4: middle estimate off by 3.2-fold (0.51 log units), on the high side; the range from low to high includes it.
By their numbers in this assay, from the lowest: compounds 4, 1, 2 and 3 (each within the scatter of the next, the first and the last beyond it).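

In this assay, cyano in place of hydroxy on this saturated ring carbon gives a 4.0-fold lower number from compound 3 to compound 4 (0.60 log units; beyond the scatter), so an exchange at this place now moves the number beyond the scatter, which the earlier exchange on the same carbon had not done. The position is thus not indifferent to the group it carries, although the step is modest and rests on a single pair, and cyano in place of hydroxymethyl gives a 2.0-fold lower number from compound 2 to compound 4 (0.30 log units; within the scatter), which leaves compound 2 and compound 4 indistinguishable on this read-out. Nothing at hand accounts for the step from hydroxy to cyano.

On these data alone, it remains open whether an amine, a carboxylic acid or a longer chain on this ring carbon would read close to compound 3 or would fall with compound 2 and compound 4. Also open, as far as these compounds go, is whether 4-hydroxypiperidin-1-yl to 4-cyanopiperidin-1-yl would give a step of similar size on any other core, as the change is seen here on one core only.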